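Swapping methoxy for fluoro on a thiosemicarbazone hydrazone

A few compounds are considered here, and "the series" means these few. Any claim that something is new, unique, unknown or untested is made for them only; others in the source may bear on it.

The series is measured in a functional assay on NCI/ADR-RES cells (Homo sapiens) for inhibition, read by sulforhodamine B assay, with a stated time of 48 h; a lower number here means a stronger inhibitor of growth, a higher number a weaker inhibitor of growth. Compound 1, `CC1=CC[C@H](C(C)(C)NC(=S)NN)CC1`, carries a free hydrazine end on the thiosemicarbazide; in this assay compound 1 gives 39300 nM. Compound 2, `COc1ccc(/C=N/NC(=S)NC(C)(C)[C@H]2CC=C(C)CC2)cc1`, closes that end as the hydrazone of a methoxy-substituted benzaldehyde; in this assay compound 2 gives 43800 nM. On the numbers shown, compound 2 stands beside compound 1: the two values lie within the usual scatter of one another, so the data do not separate them.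

Compound 3, `CC1=CC[C@H](C(C)(C)NC(=S)N/N=C/c2ccc(F)cc2)CC1`, is the one still to be measured. It differs from compound 2 in a single place: fluoro in place of methoxy on an aromatic carbon. For the measured compounds named here, no measured pair in this set reports such a substituent swap, so there is nothing to anchor the step on. Going by the values given here, since the only comparison available, compound 1 against compound 2, falls within the scatter, the expected step of a 1.0-fold lower number from compound 2 to compound 3 (0.02 log units; within the scatter) is itself expected to stay within the scatter, with no clear direction. Compound 3 is estimated at 42000 nM, with a range from 15000 nM to 110000 nM.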

Compound 3, concentration for 50% growth inhibition: > 100000 nM
Compound 3 was reported as a limit (the forecaster's own chance of this, stated with the estimate: 10%); middle value at least 2.3-fold (0.37 log units) away from the limit.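

In this assay, for the compounds shown here, the change from 4-methoxyphenyl to 4-fluorophenyl, on an aromatic carbon para to a large group, gives an at least 2.2-fold higher number from compound 2 to compound 3 (0.35 log units; beyond the scatter), the first step in this set that lies beyond the scatter. Compound 3 is reported only as a limit and not as a number, so the step fixes a minimum size and no true size: the limit of > 100000 nM in this assay, at which 1 of the 3 values shown sits.

Going by these compounds alone, this single pair shows what the earlier compounds could not: the group at this place on the aromatic ring can change the read-out, with compound 2 keeping a measured value of 43800 nM while its fluoro counterpart does not. The compounds shown hold no other group at this place, such as chloro, hydroxy or an amine, so one pair is all that speaks for this position. As far as these compounds go, whether the step follows from the arrival of fluoro or from the departure of methoxy stays open, as does how far the true value of compound 3 lies from that of compound 2.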